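Aglycone of compound 3: expected inhibition without the sugar

The source may report more compounds than this note shows. Statements on the series, on what has been measured and on what is new or still open speak of the compounds shown alone.

Three compounds have been run in an assay on HEK293T cells for inhibition of nuclear factor NF-kappa-B complex (Homo sapiens), read by a luciferase reporter, with stated times of 6 h and 8 h; a lower number here means a stronger inhibitor, a higher number a weaker inhibitor. Compound 1 `CNC(=O)c1cc(Oc2ccc(Nc3nccc(N4CCCC4)n3)cc2)ccn1` gives 3720 nM in this assay. Compound 2 `c1cc(N2CCCCC2)nc(Nc2ccc(Oc3ncnc4sccc34)cc2)n1` carries no number in this assay, recorded only as "not determined" (no result reported). Going by the values given here, compound 3 `COc1ccc(C[C@H]2C(=O)N[C@@H](C)C(=O)N(C)[C@H]3Cc4cccc(c4)Oc4cc(ccc4O[C@H]4O[C@H](CO)[C@@H](O)[C@H](O)[C@H]4O)C[C@H](C(=O)N[C@H](C)C(=O)N[C@@H](C)C(=O)N2C)N(C)C3=O)cc1`, the glycosylated macrocycle, gives 1850 nM in this assay; of the two numbers known it is the lower one, but compound 1 lies within the scatter of it, so the two cannot be separated on the data.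

Compound 4 `COc1ccc(C[C@H]2C(=O)N[C@@H](C)C(=O)N(C)[C@H]3Cc4cccc(c4)Oc4cc(ccc4O)C[C@H](C(=O)N[C@H](C)C(=O)N[C@@H](C)C(=O)N2C)N(C)C3=O)cc1` is the aglycone of compound 3. The change is hydrogen in place of 3,4,5-trihydroxy-6-(hydroxymethyl)oxan-2-yl on an oxygen on an aromatic ring, leaving a free hydroxy group where the sugar sat. Among the compounds with values here, no pair of measured compounds shows this kind of change, so the direction of the step has to be guessed from the change alone, with no measured step as a guide.

The expectation for compound 4 is a small gain in potency, a step from compound 3 to compound 4 of a 1.5-fold lower number from compound 3 to compound 4 (0.19 log units; within the scatter) in this assay, which may well fall inside the scatter. Compound 4 is therefore estimated at 1200 nM in this assay, with a range of 400 nM to 4000 nM.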

Compound 4, half-maximal inhibitory concentration: 65 nM
Compound 4: middle estimate off by 18-fold (1.27 log units), on the high side, and the stated range ends above it.
By their numbers in this assay, from the lowest: compound 4; then compounds 3 and 1 (each within the scatter of the next).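

In this assay, going by these compounds alone, replacing (3,4,5-trihydroxy-6-(hydroxymethyl)oxan-2-yl)oxy with hydroxy gives a 28-fold lower number from compound 3 to compound 4 (1.45 log units; beyond the scatter), the first step that can be read between two compounds differing in one place. This oxygen on an aromatic ring is therefore a place where the read-out responds strongly to the group attached, and the sugar is not required for inhibition in this assay, since the macrocycle without it gives the lower number. Nothing at hand accounts for the size of this step, so the result stands as an observation on one matched pair in one assay.

The compounds shown leave open whether the weaker number of compound 3 follows from the whole sugar or from any group on this oxygen, and a methyl ether, an acetyl ester or a short chain ending in an amine at the same place would begin to separate these readings. On these data alone, whether the free hydroxy group itself contributes also remains open, as the series holds no macrocycle with a plain hydrogen on that aromatic carbon in place of the hydroxy group.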